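Swapping the aryl group on a TRPV1 antagonist core

This account rests on a few compounds, and the source may have more. Where it says the series, first, only, none or still open, it means among the compounds named here.

Measured so far:
compound 1 `CC(C(=O)NCc1ccc(C(F)(F)F)nc1-c1ccccc1F)c1ccc(NS(C)(=O)=O)c(F)c1`, 63.3 nM
compound 2 `CC(C(=O)NCc1ccc(C(F)(F)F)nc1-c1cccc(Cl)c1)c1ccc(NS(C)(=O)=O)c(F)c1`, 0.5 nM

Among the compounds with values here, in an assay on CHO cells for antagonist activity at transient receptor potential cation channel subfamily V member 1 (Homo sapiens), read by FLIPR (on this read-out higher numbers stand for weaker inhibition and lower numbers for stronger inhibition), compound 2 gives the lowest of the two numbers, with compound 1 as its only neighbour. Compound 3 `CC(C(=O)NCc1ccc(C(F)(F)F)nc1-c1ccc(C(C)(C)C)cc1)c1ccc(NS(C)(=O)=O)c(F)c1` is compound 2 with one change: 4-(tert-butyl)phenyl in place of 3-chlorophenyl on an aromatic carbon. Within the data shown here, the only measured step, a 130-fold lower number from compound 1 to compound 2 (2.10 log units; beyond the scatter), shows that changing this aryl group can move this assay a great deal, but it concerns a different pair of groups and gives no direction for the present change. The estimate for compound 3 is therefore uncertain, set somewhat above compound 2 as an 8.0-fold higher number from compound 2 to compound 3 (0.90 log units; beyond the scatter), giving an expected value of 4 nM with a range from 0.5 nM to 40 nM.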

Compound 3, inhibition constant: 0.5 nM
Estimate against measurement, compound 3: 8.0-fold (0.90 log units) above, within the range that was stated.
By their numbers in this assay, from the lowest: compounds 2 and 3 (each within the scatter of the next); then compound 1.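

In this assay the change reads as no change at the digits printed from compound 2 to compound 3 (within the scatter), so this position accepts 4-(tert-butyl)phenyl, with 10 heavy atoms, as readily as 3-chlorophenyl, with 7 heavy atoms. The other step, a 130-fold lower number from compound 1 to compound 3 (2.10 log units; beyond the scatter), shows that two quite different aryl groups both stand far from 2-fluorophenyl. Nothing available here explains why these groups behave alike. On these data alone, it remains open whether an aryl group is needed at this position at all, for instance whether a simple amine such as piperidine would serve. A carboxylic acid on the phenyl ring is also untested by these compounds.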